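Tert-butoxy for oxan-4-yl on the carbonyl carbon

A few compounds are considered here, and "the series" means these few. Any claim that something is new, unique, unknown or untested is made for them only; others in the source may bear on it.

In a physicochemical assay for lipophilicity, at pH 7.4 (on this read-out higher numbers stand for higher lipophilicity and lower numbers for lower lipophilicity), compound 1 `Cc1cc(C(=O)Nc2c(F)cccc2F)nn1Cc1cc(Cl)ccc1OCc1ccccc1` gives 3.7. Compound 2 `Cc1cc(NC(=O)CC(C)(C)C)nn1Cc1cc(Cl)ccc1OCc1ccccc1` reads > 3.7, which is a limit and not a number. Compound 3 `Cc1cc(NC(=O)C2CCOCC2)nn1Cc1cc(Cl)ccc1OCc1ccccc1` reads > 3.7, also a limit. Within the data shown here, the series so far shows (the limit of > 3.7 in this assay, at which 2 of the 3 values shown sit).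

Compound 4 `Cc1cc(NC(=O)OC(C)(C)C)nn1Cc1cc(Cl)ccc1OCc1ccccc1` carries tert-butoxy in place of oxan-4-yl on a carbonyl carbon. Among the measured compounds shown here, the closest precedent, a step that the two limits leave unreadable from compound 2 to compound 3, is a change at the same carbonyl carbon but gives no size. The steps of a number no lower from compound 1 to compound 2 (the limit leaves the size open) and a number no lower from compound 1 to compound 3 (the limit leaves the size open) give a direction only. The expected change is a step that the limit leaves unreadable from compound 3 to compound 4, small and of uncertain direction. For compound 4 the estimated value is 4, with an expected range of 3.6 to 4.5.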

Compound 4, distribution coefficient: > 3.7
Compound 4 ended at the assay's limit (the forecaster's own chance of this, stated with the estimate: 70%); the middle value is on the limit's open side.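

In this assay compound 4 reads > 3.7, which is a limit of the assay and not a number. Tert-butoxy on the carbonyl carbon therefore joins neopentyl and oxan-4-yl at the same limit: the limit of > 3.7 in this assay, at which 3 of the 4 values shown sit.

Among these compounds, the one step that can be read gives a direction only: a number no lower from compound 1 to compound 4 (the limit leaves the size open). From the compounds shown here alone, the steps among compound 2, compound 3 and compound 4 cannot be read, so the order of these three groups stays open. Also open, going by these compounds, is whether a dimethylamino group or a chain ending in a carboxylic acid on this carbonyl carbon would give a measurable number.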